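Ethoxy-to-methyl swap on the thiazolidinedione-bearing ring

A few compounds are considered here, and "the series" means these few. Any claim that something is new, unique, unknown or untested is made for them only; others in the source may bear on it.

Measured so far in a functional assay on MCF7 cells (Homo sapiens), tested at 7.5 uM; on this read-out lower numbers stand for a stronger effect and higher numbers for a weaker effect at the one concentration tested:
compound 1 `CCOc1cc(/C=C2\SC(=O)NC2=O)ccc1OCC1(C)CCc2c(C)c(OCC=C(C)C)c(C)c(C)c2O1` gives 54%
compound 2 `C=CCOc1c(C)c(C)c2c(c1C)CCC(C)(COc1ccc(/C=C3\SC(=O)NC3=O)cc1OCC)O2` gives 75%
compound 3 `Cc1c(C)c2c(c(C)c1OC/C=C/c1ccccc1)CCC(C)(COc1ccc(/C=C3\SC(=O)NC3=O)cc1)O2` gives 43%

Compound 2 stands highest of the three numbers, that is weakest at the tested concentration; compound 1 lies nearest, and compound 3 furthest, both beyond the scatter. Among the compounds with values here, the single one-place step on record, a number 21 percentage points higher from compound 1 to compound 2 (beyond the scatter), concerns the chain on the ether oxygen of the shared core and does not touch the ring carrying the thiazolidinedione.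

Compound 4 `C=CCOc1c(C)c(C)c2c(c1C)CCC(C)(COc1ccc(/C=C3\SC(=O)NC3=O)cc1C)O2` differs from compound 2 by methyl in place of ethoxy on an aromatic carbon. Within the data shown here, no measured step bears on this change; compound 3, which carries no ethoxy, differs from compound 2 in two places and cannot be used as a step. The expectation for this assay is therefore a small step, a number 5 percentage points lower from compound 2 to compound 4 (within the scatter), likely within the scatter. Compound 4 is estimated at 70%, in a range from 50% to 90%.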

Compound 4, a percentage reported as activity, at one concentration (the size of the read-out at that concentration, not a potency): 8%
Beside the measured number, compound 4's estimate is 62 percentage points above it; measured number outside the range, below it.
By their numbers in this assay, from the lowest: compound 4; then compound 3; then compound 1; then compound 2.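

The earlier step touched only the chain on the ether oxygen of the shared core. In this assay, the ring carrying the thiazolidinedione proves at least as responsive: methyl in place of ethoxy, ortho to a large group, gives a number 67 percentage points lower from compound 2 to compound 4 (beyond the scatter) at this position. Nothing available explains the size of this step.

As far as these compounds go, whether the step comes from methyl itself or from the loss of ethoxy stays open, and methoxy or chlorine at this place would help separate the two. From the compounds shown here alone, whether the swap holds with other chains on the ether oxygen also remains open.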